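Methyl in place of oxolan-3-yl: three measured, one expected

A few compounds are considered here, and "the series" means these few. Any claim that something is new, unique, unknown or untested is made for them only; others in the source may bear on it.

The measured compounds are compound 1 `O=C(N/N=C/c1ccc(F)cc1)Nc1cc2c(Nc3ccc(F)c(Cl)c3)ncnc2cc1O[C@H]1CCOC1` with 28200 nM, compound 2 `CC(C)(C)c1cc(/C=N/NC(=O)Nc2cc3c(Nc4ccc(F)c(Cl)c4)ncnc3cc2O[C@H]2CCOC2)cc(C(C)(C)C)c1O` with 14500 nM, and compound 3 `COc1cc2ncnc(Nc3ccc(F)c(Cl)c3)c2cc1NC(=O)N/N=C/c1ccc(F)cc1` with 35100 nM, all in a functional assay on MCF7 cells (Homo sapiens) for cytotoxicity, read by MTT assay, with a stated time of 72 h; a lower number here means a stronger inhibitor, a higher number a weaker inhibitor.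

Compound 1 and compound 3 differ only by methyl in place of oxolan-3-yl on an oxygen on an aromatic ring, and that change gives a 1.2-fold higher number from compound 1 to compound 3 (0.10 log units; within the scatter). Compound 2 gives the lowest number of the three; its gap to compound 1 is within the scatter, its gap to compound 3 beyond it. How the core of compound 2 differs from that of compound 1 is not broken down here.

Compound 4 `COc1cc2ncnc(Nc3ccc(F)c(Cl)c3)c2cc1NC(=O)N/N=C/c1cc(C(C)(C)C)c(O)c(C(C)(C)C)c1` is not yet measured. It differs from compound 2 by methyl in place of oxolan-3-yl on an oxygen on an aromatic ring, the same change as between compound 1 and compound 3, at the same place. Because that earlier change gave a 1.2-fold higher number from compound 1 to compound 3 (0.10 log units; within the scatter), a step of similar size is expected, a 1.2-fold higher number from compound 2 to compound 4 (0.08 log units; within the scatter). Compound 4 is therefore expected to give about 17500 nM in this assay, most likely between 8000 nM and 40000 nM.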

Compound 4, half-maximal inhibitory concentration: 28300 nM
Estimate against measurement, compound 4: 1.6-fold (0.21 log units) below, within the range that was stated.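

In this assay, replacing oxolan-3-yl with methyl on the oxygen gives a 2.0-fold higher number from compound 2 to compound 4 (0.29 log units; within the scatter) and stays within the scatter. Set beside the earlier step, the change reads alike on the two cores: the same change on two cores in this assay, a 1.2-fold higher number (0.10 log units; within the scatter) from compound 1 to compound 3 and a 2.0-fold higher number (0.29 log units; within the scatter) from compound 2 to compound 4, 1.6-fold (0.20 log units) apart, within the scatter of two such steps. This shows that the small step carried over between these two pairs, but it does not show that the change has a real effect of its own on either core, nor that it would carry to any further core in the series.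

Going by these compounds, only oxolan-3-yl and methyl appear on that oxygen, so what an ethyl group, a longer chain or a chain ending in an amine would give there stays open. On these data alone, whether the step holds on a third core also stays open.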